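Shortening the Amide Side Chain on a Shared Core

The source may report more compounds than this note shows. Statements on the series, on what has been measured and on what is new or still open speak of the compounds shown alone.

Of the compounds shown here, three that share one core have been tested in an ADME assay on L929 cells (Mus musculus) for cytotoxicity, read by resazurin assay, with a stated time of 72 h; a higher number here means a weaker inhibitor, a lower number a stronger inhibitor. Compound 1 `OB1OCc2ccc(-n3cccc3)cc21` gives only a limit rather than a number: in this assay compound 1 gives > 10 ug/mL. Compound 2 `O=C(NCc1ccccc1)c1cccn1-c1ccc2c(c1)B(O)OC2` likewise reaches only the limit, giving > 10 ug/mL in this assay. Compound 3 `COc1ccc(CNC(=O)c2cccn2-c2ccc3c(c2)B(O)OC3)cc1` also sits at the limit, giving > 10 ug/mL in this assay. Compound 3 therefore stands exactly where the other measured compounds stand; the step that the two limits leave unreadable from compound 2 to compound 3 cannot be read in size, and what the measurements show is summed up by the limit of > 10 ug/mL in this assay, at which 3 of the 3 values shown sit.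

Compound 4 `CCNC(=O)c1cccn1-c1ccc2c(c1)B(O)OC2` differs from compound 3 by methyl in place of 4-methoxyphenyl on a saturated chain carbon bound to an amide-type nitrogen. Among the compounds with values here, no measured step bears on this change, since the step that the two limits leave unreadable from compound 2 to compound 3 concerns a different part of the molecule and is itself unreadable. The step that the limit leaves unreadable from compound 3 to compound 4 is expected to be none beyond the scatter. Compound 4 is estimated at 15 ug/mL, with a range from 7 ug/mL to 40 ug/mL, most probably again reported only as a limit.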

Compound 4, half-maximal inhibitory concentration: > 10 ug/mL
Compound 4: a limit, no number (the forecaster's own chance of this, stated with the estimate: 85%); the middle value does not contradict the limit.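

In this assay compound 4 gives only a limit, so no step from compound 1, compound 2 or compound 3 to compound 4 can be read, and all four compounds stand at the same result: the limit of > 10 ug/mL in this assay, at which 4 of the 4 values shown sit.

What the compounds shown leave open is the concentration at which any of them harms these cells, and whether the amide side chain alters it.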